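Benzyl in place of phenyl: expected cytotoxicity limit

The source may report more compounds than this note shows. Statements on the series, on what has been measured and on what is new or still open speak of the compounds shown alone.

Compound 1 `CCCCSC(=S)N1CCN(C(=S)SC(=S)N(C)C)CC1` was tested in an ADME assay on HeLa cells (Homo sapiens) for cytotoxicity, read by MTT assay, with a stated time of 24 h; on this read-out higher numbers stand for weaker inhibition and lower numbers for stronger inhibition. In this assay compound 1 gives > 5000000 nM, which is a limit of the assay and not a number. Compound 2 `CN(C)C(=S)SC(=S)N1CCN(C(=S)Nc2ccccc2)CC1` carries anilino in place of butylsulfanyl on a thiocarbonyl carbon. In this assay compound 2 gives > 5000000 nM, again a limit rather than a number. The step that the two limits leave unreadable from compound 1 to compound 2 cannot be sized, both of its ends being limits. Compound 2 therefore stands at the limit of > 5000000 nM in this assay, at which 2 of the 2 values shown sit, where every value shown sits.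

Compound 3 `CN(C)C(=S)SC(=S)N1CCN(C(=S)NCc2ccccc2)CC1` carries benzyl in place of phenyl on an amide-type nitrogen. For the measured compounds named here, the only measured step bearing on this change is unreadable, so nothing beyond the scatter can be expected in this assay. Compound 3 is estimated at 5000000 nM, within a range of 1000000 nM to 20000000 nM. The expected step is a number no higher from compound 2 to compound 3 (the limit leaves the size open), most probably reported once more as a limit rather than a number.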

Compound 3, half-maximal inhibitory concentration: > 5000000 nM
Compound 3: no number, only a limit (the forecaster's own chance of this, stated with the estimate: 85%); the middle value lies on the limit itself.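

Compound 3 also gives a limit and not a number, so no step among compound 1, compound 2 and compound 3 can be read in this assay: the limit of > 5000000 nM in this assay, at which 3 of the 3 values shown sit.

The compounds shown leave open whether butylsulfanyl, anilino or benzylamino on a thiocarbonyl carbon makes any difference to this read-out.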